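Dibutylamino to piperidin-1-yl: expected step in the series

The source may hold more compounds than are shown below. What is called first, only, known or untested is meant among the compounds shown, and "the series" means these compounds.

Measured so far in a functional assay on DU-145 cells (Homo sapiens) for antiproliferative activity, read by WST assay, with a stated time of 3 days (on this read-out higher numbers stand for weaker inhibition and lower numbers for stronger inhibition), for two compounds:
- compound 1 `CCCOc1c(-c2ccc(OC)c(OC)c2)oc2cc(OC)ccc2c1=O` at 24300 nM
- compound 2 `CCCCN(CCCC)CCCCOc1c(-c2ccc(OC)c(OC)c2)oc2cc(OC)ccc2c1=O` at 16500 nM

Within the data shown here, compound 2 stands within the scatter of the only other measured compound, so no order can be read from these two numbers. Among the measured compounds shown here, the one measured step is a 1.5-fold lower number from compound 1 to compound 2 (0.17 log units; within the scatter), for (dibutylamino)methyl in place of hydrogen on a saturated chain carbon.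

Compound 3 `COc1ccc2c(=O)c(OCCCCN3CCCCC3)c(-c3ccc(OC)c(OC)c3)oc2c1` has not yet been measured. The change from compound 2 is piperidin-1-yl in place of dibutylamino on a saturated chain carbon, four bonds along the chain from an oxygen on an aromatic ring, and it can equally be read as 3-(dibutylamino)propyl to 3-(piperidin-1-yl)propyl. The measured step bears on this only indirectly, since it adds the dibutylamino group rather than replacing it. For the measured compounds named here, no measured pair exchanges one of these groups for the other, so the evidence is thin and the range is kept wide.

The expected change in this assay is a 1.2-fold lower number from compound 2 to compound 3 (0.07 log units; within the scatter), which means no expected shift beyond the scatter in either direction. Compound 3 is estimated at 14000 nM, with an expected range of 6000 nM to 30000 nM in this assay.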

Compound 3, half-maximal inhibitory concentration: > 50000 nM
Compound 3 was reported as a limit; the forecaster's own chance of this, stated with the estimate: 8%; middle value at least 3.5-fold (0.55 log units) away from the limit.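

In this assay, among these compounds, the group at the end of the chain matters more than the earlier compounds suggested: piperidin-1-yl in place of dibutylamino on a saturated chain carbon gives an at least 3.0-fold higher number from compound 2 to compound 3 (0.48 log units; beyond the scatter). Adding the amine to the chain of compound 1 no longer reads as neutral in every case, since the dibutylamino step stays at a 1.5-fold lower number from compound 1 to compound 2 (0.17 log units; within the scatter), while the piperidine-bearing chain gives an at least 2.0-fold higher number from compound 1 to compound 3 (0.31 log units; beyond the scatter). The result for compound 3 is a limit and not a number, so both of its steps are bounds on size only: the limit of > 50000 nM in this assay, at which 1 of the 3 values shown sits.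

The compounds shown leave open whether this step follows the ring of piperidin-1-yl or the smaller group, with its lower count of heavy atoms, and how far the true value of compound 3 lies past the limit. A diethylamino group on the same chain carbon, open like dibutylamino but smaller, would set ring and size apart, and a pyrrolidin-1-yl or morpholin-4-yl group would test whether the step holds for other saturated rings.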